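The compounds below may be only part of what the source reports. "The series", "measured", "known", "first", "only" and "open" are said of these compounds alone.

Compound 3, `CC[C@H](C)[C@H](N)CN(C(=O)[C@@H]1C[C@H]1c1ccccc1)c1ccc(-c2ccc(NS(C)(=O)=O)cc2)cc1`, stands highest of the three measured numbers in a functional assay for agonist activity at G protein-coupled receptor 88 (Homo sapiens), read by HTRF and cAMP accumulation (a lower number here means that less compound is needed, a higher number that more compound is needed for the effect), where compound 3 gives 1200 nM. Compound 1, `CCc1ccc(-c2ccc(N(C[C@@H](N)[C@@H](C)CC)C(=O)[C@@H]3C[C@H]3c3ccccc3)cc2)cc1`, gives 44 nM in this assay, and compound 2, `CC[C@H](C)[C@H](N)CN(C(=O)[C@@H]1C[C@H]1c1ccccc1)c1ccc(-c2ccc(C(F)(F)F)cc2)cc1`, gives 340 nM. The two steps that lead into compound 3 are a 27-fold higher number from compound 1 to compound 3 (1.44 log units; beyond the scatter) and a 3.5-fold higher number from compound 2 to compound 3 (0.55 log units; beyond the scatter); the step of a 7.7-fold higher number from compound 1 to compound 2 (0.89 log units; beyond the scatter) connects the other two compounds. The unmeasured compound 4, `CC[C@H](C)[C@H](N)CN(C(=O)[C@@H]1C[C@H]1c1ccccc1)c1ccc(-c2ccc(CN)cc2)cc1`, differs from compound 3 in one place: aminomethyl in place of methanesulfonamido on an aromatic carbon. For the measured compounds named here, no measured step exchanges the methanesulfonamido group for an aminomethyl group, so the three known steps bear on the question only in showing that a change of this group shifts the number in this assay by modest to large amounts. Since compound 3 already sits at the highest number and each step into it was sizeable, a move back down from compound 3 is as plausible as a further rise, and the direction stays uncertain. Compound 4 is therefore expected to give about 900 nM in this assay, which means an estimated step of a 1.3-fold lower number from compound 3 to compound 4 (0.12 log units; within the scatter), with a wide range from 150 nM to 5000 nM.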

Compound 4, half-maximal effective concentration: > 30000 nM
Compound 4 was reported as a limit; the forecaster's own chance of this, stated with the estimate: 10%; at least 33-fold (1.52 log units) between middle value and limit.
By their numbers in this assay, from the lowest: compound 1; then compound 2; then compound 3. At a limit, above all of these: compound 4.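

Compound 4 stands at a limit in this assay, not at a number: the limit of > 30000 nM in this assay, at which 1 of the 4 values shown sits. The earlier compounds shown here showed that this position, on an aromatic carbon para to a large group, gives measurable numbers with ethyl, trifluoromethyl and methanesulfonamido, whereas aminomethyl brings an at least 25-fold higher number from compound 3 to compound 4 (1.39 log units; beyond the scatter) and an at least 88-fold higher number from compound 2 to compound 4 (1.94 log units; beyond the scatter), so the new group falls outside the range those three span. The sharpest contrast lies in the smallest change, amino in place of the terminal methyl of the ethyl group, which gives an at least 680-fold higher number from compound 1 to compound 4 (2.83 log units; beyond the scatter) and shows that a single exchange at the end of this short chain can decide whether any number is reached at all.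

The compounds shown leave open whether this result follows the amine nitrogen itself or its place on the chain, which a hydroxymethyl group, an amino group set directly on the ring or a longer aminoethyl chain would begin to separate. As far as these compounds go, they also leave open how far past the limit compound 4 lies, so the full size of all three steps remains unknown.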